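Swapping ethyl for amino on the shared core

The source may hold more compounds than are shown below. What is called first, only, known or untested is meant among the compounds shown, and "the series" means these compounds.

Measured in an ADME assay on H1-HeLa cells (Homo sapiens) for cytotoxicity, read by MTT assay, with a stated time of 3 days; a higher number here means that more compound is tolerated, a lower number that less compound is tolerated:
- Compound 1 `CCOC(=O)c1cc2ccc(Oc3ccnc(C(=O)NC)c3)cc2s1`: > 100000 nM, which is a limit of the assay
- Compound 2 `CCOC(=O)c1sc2cc(Oc3ccnc(C(=O)NC)c3)ccc2c1C`: 50900 nM
- Compound 3 `CCOC(=O)c1sc2cc(Oc3ccnc(C(=O)NC)c3)ccc2c1CC`: 35200 nM

For the measured compounds named here, compound 3 stands within the scatter of compound 2, as a 1.4-fold lower number from compound 2 to compound 3 (0.16 log units; within the scatter) shows, and these two hold the only actual numbers so far. Compound 4 `CCOC(=O)c1sc2cc(Oc3ccnc(C(=O)NC)c3)ccc2c1N` has not yet been measured. It carries amino in place of ethyl on an aromatic carbon.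

Going by the values given here, no measured step involves amino, so the nearest guides are the steps that put methyl or ethyl in place of hydrogen on an aromatic carbon: an at least 1.9-fold lower number from compound 1 to compound 2 (0.29 log units; that floor lies within the scatter) and an at least 2.8-fold lower number from compound 1 to compound 3 (0.45 log units; beyond the scatter). Both start from a limit, so they give only a minimum size. Taking away the ethyl of compound 3 could undo part of an at least 2.8-fold lower number from compound 1 to compound 3 (0.45 log units; beyond the scatter), but amino is not hydrogen, so only a small rise in this assay is expected, perhaps nothing beyond the scatter. The expected step is a 1.4-fold higher number from compound 3 to compound 4 (0.15 log units; within the scatter). Compound 4 is estimated at 50000 nM, with an expected range of 18000 nM to 100000 nM.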

Compound 4, half-maximal cytotoxic concentration: 110 nM
The estimate for compound 4 lay 450-fold (2.66 log units) above the measured number; measured number below the stated range.
By their numbers in this assay, from the lowest: compound 4; then compounds 3 and 2 (each within the scatter of the next). At a limit, above all of these: compound 1.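

In this assay, amino on this aromatic carbon, two ring bonds from the ring sulfur, does something that neither methyl nor ethyl there gave any sign of, with a 320-fold lower number from compound 3 to compound 4 (2.51 log units; beyond the scatter) and a 460-fold lower number from compound 2 to compound 4 (2.67 log units; beyond the scatter). Among the compounds shown, this place is therefore far from indifferent to its group: the two carbon groups sit within the scatter of each other, while the swap to a nitrogen-bearing group that adds a hydrogen-bond donor and acceptor moves the number by a large step. Against hydrogen, an at least 900-fold lower number from compound 1 to compound 4 (2.95 log units; beyond the scatter) gives only a minimum size for the step, which starts from a limit: the limit of > 100000 nM in this assay, at which 1 of the 4 values shown sits.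

Which feature of amino matters remains open. A methylamino, a dimethylamino, an acetylamino or a hydroxyl group at this place would help to separate these possibilities.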